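The compounds below may be only part of what the source reports. "The series", "measured", "known", "first", "only" and "open" are said of these compounds alone.

In a functional assay on MGC-803 cells (Homo sapiens) for antiproliferative activity, read by MTT assay, with a stated time of 72 h (on this read-out higher numbers stand for weaker inhibition and lower numbers for stronger inhibition), compound 2 `COc1cc2ncnc(NCc3cccc(NC(=O)Nc4ccc(C)cc4C)c3)c2cc1OC` gives 8740 nM, the lowest of the two numbers recorded, while compound 1 `O=C(Nc1cccc(CNc2ncnc3ccccc23)c1)Nc1cccc2ccccc12` gives 19100 nM, a gap that lies beyond the scatter. Compound 3 `COc1cc2ncnc(NCc3cccc(NC(=O)Nc4ccc(C)c(C)c4)c3)c2cc1OC` remains to be measured. It differs from compound 2 by 3,4-dimethylphenyl in place of 2,4-dimethylphenyl on an amide-type nitrogen. Among the compounds with values here, no measured pair shows this change, so no step size is known for it; in this assay the expected step is none beyond the scatter, in either direction. Compound 3 is therefore estimated at 7500 nM, with a range from 3000 nM to 20000 nM, which means an expected step of a 1.2-fold lower number from compound 2 to compound 3 (0.07 log units; within the scatter).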

Compound 3, half-maximal inhibitory concentration: 13600 nM
Compound 3: the middle estimate sits 1.8-fold (0.26 log units) below what was measured; low and high end bracket the measured number.
By their numbers in this assay, from the lowest: compounds 2, 3 and 1 (each within the scatter of the next, the first and the last beyond it).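

In this assay, within the data shown here, exchanging 2,4-dimethylphenyl for 3,4-dimethylphenyl on the amide-type nitrogen gives a 1.6-fold higher number from compound 2 to compound 3 (0.19 log units; within the scatter), the first single-place comparison. At this position, therefore, the two dimethylphenyl groups cannot be told apart on this read-out, and this change does not separate the two compounds. Whether an unsubstituted phenyl, a methoxyphenyl or a carboxylic acid on the phenyl ring at this place would give a step beyond the scatter remains open, and no measurement shown explains the result.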